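Swapping Methyl for Fluoro on an Aromatic Ring

The compounds below may be only part of what the source reports. "The series", "measured", "known", "first", "only" and "open" are said of these compounds alone.

Measured compounds:
Compound 1 `O=C(CCC1=CCN(CCCc2ccc(Cl)cc2)C1=O)NO`: 2200 nM
Compound 2 `Cc1ccc(CN2CC=C(CCC(=O)NO)C2=O)cc1`: 4280 nM
Compound 3 `CC(C)(C)c1ccc(CCCN2CC=C(CCC(=O)NO)C2=O)cc1`: 2200 nM

In a functional assay on NUGC-3 cells (Homo sapiens) for inhibition, read by sulforhodamine B assay (on this read-out lower numbers stand for stronger inhibition of growth and higher numbers for weaker inhibition of growth), compound 2 stands highest of the three numbers, yet compound 1 and compound 3 both lie within the scatter of it, so no order among the three can be claimed. Compound 4 `O=C(CCC1=CCN(Cc2ccc(F)cc2)C1=O)NO` differs from compound 2 in one place: fluoro in place of methyl on an aromatic carbon. Among the compounds with values here, the only measured step that bears on this is also a swap of one group on an aromatic carbon, no change at the digits printed from compound 1 to compound 3 (within the scatter), which left the number unchanged within the scatter. By the same token the step from compound 2 to compound 4 is expected to stay within the scatter, a 1.1-fold lower number from compound 2 to compound 4 (0.03 log units; within the scatter). Compound 4 is therefore estimated at 4000 nM, with a range from 1800 nM to 9000 nM.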

Compound 4, concentration for 50% growth inhibition: 6060 nM
For compound 4 the middle estimate is 1.5-fold (0.18 log units) below the measured one; measured number inside the range.
By their numbers in this assay, from the lowest: compounds 1, 3, 2 and 4 (each within the scatter of the next, the first and the last beyond it).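

In this assay the swap of fluoro in place of methyl, on an aromatic carbon para to a large group, gives a 1.4-fold higher number from compound 2 to compound 4 (0.15 log units; within the scatter) and so shows no readable shift. Alongside no change at the digits printed from compound 1 to compound 3 (within the scatter) on a longer chain, this makes two single-group swaps on an aromatic carbon that stay within the scatter, now also with the shorter chain of compound 2. Nothing measured here accounts for the result. From the compounds shown here alone, whether an amine or a carboxylic acid on that same carbon would move the number beyond the scatter remains open.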